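Amide variation at the aromatic amine of a triazolopyrimidine series

The source may hold more compounds than are shown below. What is called first, only, known or untested is meant among the compounds shown, and "the series" means these compounds.

Measured compounds:
Compound 1, `Nc1nc(-c2ccccc2)nc2c1nnn2Cc1ccccc1`, gives 5.6 nM in an assay (strain Wistar) for displacement of a labelled ligand from adenosine receptor A1 (Rattus norvegicus), read by scintillation counting; a lower number here means a stronger inhibitor, a higher number a weaker inhibitor.
Compound 2, `O=C(Nc1nc(-c2ccccc2)nc2c1nnn2Cc1ccccc1)c1cccc(F)c1`, gives 22 nM in this assay.
Compound 3, `O=C(Nc1nc(-c2ccccc2)nc2c1nnn2Cc1ccccc1)C1CCCC1`, gives 2.5 nM in this assay.

Compound 3 has the lowest number of the three; the nearest is compound 1 (a 2.2-fold lower number from compound 1 to compound 3 (0.35 log units; beyond the scatter)), the furthest is compound 2 (an 8.8-fold lower number from compound 2 to compound 3 (0.94 log units; beyond the scatter)). Compound 4, `O=C(Nc1nc(-c2ccccc2)nc2c1nnn2Cc1ccccc1)c1ccc([N+](=O)[O-])cc1`, has not yet been measured in this assay. It differs from compound 3 in that (4-nitrophenyl in place of cyclopentyl on a carbonyl carbon).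

Among the measured compounds shown here, the only step that bears directly on this change is the one from the 3-fluorophenyl amide to the cyclopentyl amide, an 8.8-fold lower number from compound 2 to compound 3 (0.94 log units; beyond the scatter), which runs in the opposite direction to the step now considered. Compound 4 carries an aromatic ring on the carbonyl carbon, as compound 2 does, so its number is expected to move back toward that of compound 2. The step from compound 3 to compound 4 is therefore estimated as a 10-fold higher number from compound 3 to compound 4 (1.00 log units; beyond the scatter). Compound 4 is expected to give about 25 nM in this assay, within a range from 8 nM to 80 nM.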

Compound 4, inhibition constant: 24 nM
The estimate for compound 4 lay 1.0-fold (0.02 log units) above the measured number, and the stated range covers the measured number.
By their numbers in this assay, from the lowest: compound 3; then compound 1; then compounds 2 and 4 (each within the scatter of the next).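

In this assay compound 4 and compound 2 cannot be told apart (a 1.1-fold higher number from compound 2 to compound 4 (0.04 log units; within the scatter)), although 4-nitrophenyl and 3-fluorophenyl carry different groups on the ring. Placing 4-nitrophenyl on the carbonyl carbon in place of cyclopentyl (a 9.6-fold higher number from compound 3 to compound 4 (0.98 log units; beyond the scatter)) gives a step of similar size to the one seen with compound 2, and the amide again has a higher number than the free amine (a 4.3-fold higher number from compound 1 to compound 4 (0.63 log units; beyond the scatter)), so among these compounds both phenyl amides lie on one side of compound 1 and the cyclopentyl amide on the other. No evidence here accounts for this split between the two kinds of ring.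

Compound 3 is the only amide shown with a non-aromatic ring, so it remains open whether a cyclohexyl ring or a longer alkyl chain would follow it. An unsubstituted phenyl ring or a pyridine ring on the carbonyl carbon would show whether the phenyl amides' position holds more widely.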